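Swapping 4-chlorophenyl for pyridin-2-yl in compound 3

The source may report more compounds than this note shows. Statements on the series, on what has been measured and on what is new or still open speak of the compounds shown alone.

Within the data shown here, in a functional assay on HEY cells (Homo sapiens) for cytotoxicity, read by MTT assay, with a stated time of 72 h (on this read-out lower numbers stand for stronger inhibition and higher numbers for weaker inhibition), compound 3 `N[C@H]1CC[C@H](Nc2c(C(=O)NCc3ccc(Cl)cc3)nc(Br)c3cccnc23)CC1` gives 1000 nM, the lowest number so far, while compound 2 `COc1cccc(CNC(=O)c2nc(Br)c3cccnc3c2N[C@H]2CC[C@H](N)CC2)c1` gives 7000 nM. Compound 1 `N[C@H]1CC[C@H](Nc2c(C(=O)NCc3ccco3)nc(Br)c3cccnc23)CC1` reads > 10000 nM, which is a limit and not a number. Compound 4 `N[C@H]1CC[C@H](Nc2c(C(=O)NCc3ccccn3)nc(Br)c3cccnc23)CC1` carries pyridin-2-yl in place of 4-chlorophenyl on a saturated chain carbon bound to an amide-type nitrogen. Two measured steps at this place end at compound 3: a 7.0-fold lower number from compound 2 to compound 3 (0.85 log units; beyond the scatter) and an at least 10-fold lower number from compound 1 to compound 3 (1.00 log units; beyond the scatter). Since neither 3-methoxyphenyl nor furan-2-yl matched 4-chlorophenyl, a modest rise is expected in this assay. The expected step is a 5.0-fold higher number from compound 3 to compound 4 (0.70 log units; beyond the scatter). Compound 4 is estimated at 5000 nM, within a range of 1800 nM to 15000 nM.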

Compound 4, half-maximal inhibitory concentration: > 20000 nM
Compound 4 ended at the assay's limit; the forecaster's own chance of this, stated with the estimate: 30%; middle value at least 4.0-fold (0.60 log units) from the limit.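

In this assay, the reading for compound 4 is a limit and not a number: the limit of > 20000 nM in this assay, at which 1 of the 4 values shown sits. Even so, pyridin-2-yl gives an at least 20-fold higher number from compound 3 to compound 4 (1.30 log units; beyond the scatter) and an at least 2.8-fold higher number from compound 2 to compound 4 (0.45 log units; beyond the scatter), so on this saturated chain carbon bound to an amide-type nitrogen, a six-membered aromatic ring alone does not secure the value of compound 3. The step between compound 1 and compound 4 cannot be read, as both values are limits. Still open, as far as these compounds go, is whether the chlorine carries the difference. Plain phenyl or 4-bromophenyl at this place would test that.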